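The source may report more compounds than this note shows. Statements on the series, on what has been measured and on what is new or still open speak of the compounds shown alone.

In a functional assay on A549 cells (Homo sapiens) for cytotoxicity (a lower number here means a stronger inhibitor, a higher number a weaker inhibitor), compound 1 (`C=C/C=C\[C@H](C)[C@H](OC(N)=O)[C@@H](C)[C@H](O)[C@@H](C)C/C(C)=C\[C@H](C)[C@@H](O)[C@@H](C)/C=C\CCc1ccc(C)c(F)c1`) gives 4000 nM. Among the three compounds measured it stands level with compound 3 at the digits shown, the two together giving the highest numbers of the set. Compound 3 (`C=C/C=C\[C@H](C)[C@H](OC(N)=O)[C@@H](C)[C@H](O)[C@@H](C)C/C(C)=C\[C@H](C)[C@@H](O)[C@@H](C)/C=C\CCc1ccsc1`) gives 4000 nM, and compound 2 (`C=C/C=C\[C@H](C)[C@H](OC(N)=O)[C@@H](C)[C@H](O)[C@@H](C)C/C(C)=C\[C@H](C)[C@@H](O)[C@@H](C)/C=C\CCc1cc(F)cc(F)c1`) gives 1000 nM. The measured steps that exchange the aryl group on the saturated chain carbon are a 4.0-fold lower number from compound 1 to compound 2 (0.60 log units; beyond the scatter) and no change at the digits printed from compound 1 to compound 3 (within the scatter); the third, a 4.0-fold higher number from compound 2 to compound 3 (0.60 log units; beyond the scatter), links the other two. Compound 4 (`C=C/C=C\[C@H](C)[C@H](OC(N)=O)[C@@H](C)[C@H](O)[C@@H](C)C/C(C)=C\[C@H](C)[C@@H](O)[C@@H](C)/C=C\CCc1cccc(O)c1`) differs from compound 1 in one place: 3-hydroxyphenyl in place of 3-fluoro-4-methylphenyl on a saturated chain carbon, two bonds along the chain from a double-bonded chain carbon. Going by the values given here, neither the step to compound 2 nor the step to compound 3 brings in a hydroxyl, so no measured step tells directly how a hydrogen-bond donor on this ring is received; they show only that exchanging this aryl group moves this assay by a modest amount at most. For the step to compound 4 a change of modest size or none beyond the scatter is therefore expected, with a lower number at least as likely as a higher one because a 4.0-fold lower number from compound 1 to compound 2 (0.60 log units; beyond the scatter) already showed a lowering on exchanging this aryl group. The estimate for compound 4 in this assay is 3000 nM, between 1000 nM and 8000 nM, which means a 1.3-fold lower number from compound 1 to compound 4 (0.12 log units; within the scatter).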

Compound 4, half-maximal inhibitory concentration: 190 nM
Compound 4: the middle estimate sits 16-fold (1.20 log units) above what was measured; measured number outside the range, below it.
By their numbers in this assay, from the lowest: compound 4; then compound 2; then compounds 1 and 3 (each within the scatter of the next).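

Going by these compounds alone, on this saturated chain carbon, the aryl exchange can do far more in this assay than the earlier compounds showed: 3-hydroxyphenyl in place of 3-fluoro-4-methylphenyl gives a 21-fold lower number from compound 1 to compound 4 (1.32 log units; beyond the scatter) and the same group in place of thiophen-3-yl gives a 21-fold lower number from compound 3 to compound 4 (1.32 log units; beyond the scatter), both large steps where the earlier exchanges had been modest at most. Compound 4 also improves on the best earlier aryl group, with a 5.3-fold lower number from compound 2 to compound 4 (0.72 log units; beyond the scatter), so it is the strongest inhibitor of the four, and among these compounds the only one with a hydroxyl on the ring gives the lowest number. No measurement shown here explains why this group lowers the number so far.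

On these data alone, the step from compound 1 to compound 4 removes the fluorine and the methyl and adds the hydroxyl in one exchange, so the share of each remains unknown, and a plain phenyl ring would be needed to separate them. As far as these compounds go, it also remains open whether the hydroxyl itself is required, or whether a methoxy group, an amine or a carboxylic acid in its place on the phenyl ring would give a similarly low number.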